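The source may report more compounds than this note shows. Statements on the series, on what has been measured and on what is new or still open speak of the compounds shown alone.

Compound 1 `Clc1ccccc1Cn1nnc2c(NC3CC3)nc(-c3ccccc3)nc21`: 11 nM
Compound 2 `Clc1ccccc1Cn1nnc2c(NC3CCC3)nc(-c3ccccc3)nc21`: 24 nM

In an assay on Cerebral cortex for displacement of a labelled ligand from adenosine receptor A1 (Bos taurus) (on this read-out lower numbers stand for stronger inhibition and higher numbers for weaker inhibition), compound 1 gives 11 nM, and compound 2 gives 24 nM. Going by the values given here, compound 2 thus stands at the higher of the two numbers measured so far, set apart from compound 1 by a 2.2-fold higher number from compound 1 to compound 2 (0.34 log units; beyond the scatter), a step that came with cyclobutyl in place of cyclopropyl on a nitrogen on an aromatic ring. Compound 3 `Clc1ccccc1Cn1nnc2c(NC3CCCCC3)nc(-c3ccccc3)nc21` carries the same kind of change one size further: cyclohexyl in place of cyclobutyl on a nitrogen on an aromatic ring. Among the compounds with values here, the only measured step that bears on this is the one from compound 1 to compound 2, where enlarging the ring on that nitrogen raised the number by a modest amount. Going on to a still larger ring is expected, on the same line, to raise the number again by a comparable or somewhat larger margin, though a step of that size could also fall within the scatter. For compound 3 the expected step from compound 2 is a 1.9-fold higher number from compound 2 to compound 3 (0.27 log units; within the scatter). Compound 3 is therefore estimated at 45 nM in this assay, with a range from 14 nM to 150 nM.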

Compound 3, inhibition constant: 34 nM
Estimate against measurement, compound 3: 1.3-fold (0.12 log units) above, within the range that was stated.
By their numbers in this assay, from the lowest: compound 1; then compounds 2 and 3 (each within the scatter of the next).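

In this assay, going by these compounds alone, the change from cyclobutyl to cyclohexyl on a nitrogen on an aromatic ring amounts to a 1.4-fold higher number from compound 2 to compound 3 (0.15 log units; within the scatter) and so separates the two larger rings by no more than the usual variation between repeats, which the first pair of compounds could not show. Set against the smallest ring, the same position gives a 3.1-fold higher number from compound 1 to compound 3 (0.49 log units; beyond the scatter) as the widest gap so far, and compound 1, with cyclopropyl, holds the lowest number of the three, since its steps to both other compounds lie beyond the scatter. Thus the position tolerates a cyclohexyl group with only a modest penalty relative to cyclopropyl, though no information is available to explain this behaviour.

Whether a ring is needed on this nitrogen at all remains open, as the compounds shown do not say how an open chain such as isopropyl or n-butyl, or a plain amino group, would compare. On these data alone, it also remains open how a ring carrying a heteroatom, such as tetrahydropyranyl or piperidinyl, would behave at this position.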